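The source may report more compounds than this note shows. Statements on the series, on what has been measured and on what is new or still open speak of the compounds shown alone.

In a functional assay on MCF7 cells (Homo sapiens) for cytotoxicity, read by MTT assay, with a stated time of 4 days (on this read-out lower numbers stand for stronger inhibition and higher numbers for weaker inhibition), compound 1 `Cc1c(O)ccc2c1[C@H](Cn1cc(-c3ccc(F)cc3)nn1)[C@@]13CC(=O)[C@@](C)(CC[C@@H]21)C3` gives only a limit, > 20000 nM. Compound 2 `C=C1C[C@]23C[C@@]1(O)CC[C@@H]2c1cccc(C)c1[C@@H]3Cn1cc(-c2ccc(F)cc2)nn1` likewise gives only a limit, > 20000 nM. Compound 3 `C=C1C(=O)[C@]23C[C@@]1(O)CC[C@H]2c1ccc(O)c(C)c1[C@@H]3Cn1cc(-c2ccc(Cl)cc2)nn1`, by contrast, gives a measured number, 2470 nM. Compound 4 `C=C1C[C@]23C[C@@]1(O)CC[C@@H]2c1cccc(C)c1[C@@H]3Cn1cc(-c2ccc(C(F)(F)F)cc2)nn1` differs from compound 2 by trifluoromethyl in place of fluoro on an aromatic carbon. Within the data shown here, compound 2 stands at the limit of > 20000 nM in this assay, at which 2 of the 3 values shown sit, so no step between measured compounds shows what this change does, and no shift beyond the usual scatter is expected in this assay, in either direction; the step expected here is a number no higher from compound 2 to compound 4 (the limit leaves the size open). Compound 4 is therefore expected to give about 20000 nM in this assay, within a range from 8000 nM to 50000 nM, most likely reported once more as a limit rather than a number.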

Compound 4, half-maximal inhibitory concentration: > 20000 nM
Compound 4 gave a limit, no number; the forecaster's own chance of this, stated with the estimate: 70%; the middle value sits exactly at the limit.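

Compound 2 and compound 4 both give only limits, so no step between them can be read: the limit of > 20000 nM in this assay, at which 3 of the 4 values shown sit.

The compounds shown leave open whether trifluoromethyl in place of fluoro changes the result at all in this assay.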